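This account rests on a few compounds, and the source may have more. Where it says the series, first, only, none or still open, it means among the compounds named here.

Compounds measured so far:
compound 1, `CCCc1cc(N)c2cc(NC(=O)/C=C/c3ccc(F)cc3)ccc2n1`, 130 nM
compound 2, `CCCc1cc(N)c2cc(NC(=O)/C=C/c3cccc(Cl)c3)ccc2n1`, 1100 nM

In an assay on isolated protein for displacement of a labelled ligand from melanin-concentrating hormone receptor 1 (Homo sapiens) (on this read-out higher numbers stand for weaker inhibition and lower numbers for stronger inhibition), compound 2 holds the highest of the two numbers; its nearest neighbour is compound 1, and the gap is an 8.5-fold higher number from compound 1 to compound 2 (0.93 log units; beyond the scatter). Compound 3, `CCCc1cc(N)c2cc(NC(=O)/C=C/c3ccc(Cl)cc3Cl)ccc2n1`, has not yet been measured. It differs from compound 2 in one place: 2,4-dichlorophenyl in place of 3-chlorophenyl on a double-bonded chain carbon bound to a double-bonded chain carbon. Going by the values given here, the only measured step, an 8.5-fold higher number from compound 1 to compound 2 (0.93 log units; beyond the scatter), bears on this change, since it too swaps the substituent on the phenyl ring at the same place, and it was a modest step beyond the scatter. That step shows that a 4-substituted phenyl gave the lower number, and compound 3 carries a chlorine at the 4-position again, with a second chlorine added at the 2-position. Compound 3 is therefore expected to show a step of a 2.8-fold lower number from compound 2 to compound 3 (0.44 log units; beyond the scatter) in this assay. The estimate for compound 3 is 400 nM, in a range from 100 nM to 1600 nM.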

Compound 3, half-maximal inhibitory concentration: 6.6 nM
Compound 3: the middle estimate sits 61-fold (1.78 log units) above what was measured; measured number outside the range, below it.
By their numbers in this assay, from the lowest: compound 3; then compound 1; then compound 2.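

In this assay, 2,4-dichlorophenyl in place of 3-chlorophenyl brings a 170-fold lower number from compound 2 to compound 3 (2.22 log units; beyond the scatter) and in place of 4-fluorophenyl brings a 20-fold lower number from compound 1 to compound 3 (1.29 log units; beyond the scatter) at this place on the chain. The first pair had shown only a modest step from changing the phenyl substituent, whereas compound 3 shows that a change at this same place can shift the number much further, and compound 3 now holds the lowest number of the three, with both of its steps beyond the scatter. Nothing measured here explains why this group gives so large a step.

The compounds shown do not separate the contributions of the two chlorines, so it remains open how 2-chlorophenyl or 4-chlorophenyl alone would compare with 2,4-dichlorophenyl. Also open, from the compounds shown here alone, is how a methoxy or trifluoromethyl group in place of either chlorine would behave.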